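The source may report more compounds than this note shows. Statements on the series, on what has been measured and on what is new or still open speak of the compounds shown alone.

Measured compounds:
Compound 1 `COc1ccc(Br)c(-c2nc3ccccc3[nH]2)c1O`, 2480 nM in an assay for inhibition of Alpha amylase (Homo sapiens), with a stated time of 10 min; a higher number here means a weaker inhibitor, a lower number a stronger inhibitor
Compound 2 `COc1ccc(Br)c(-c2nc3cc(F)ccc3[nH]2)c1O`, 2170 nM in this assay
Compound 3 `COc1cc(-c2nc3cc(Cl)ccc3[nH]2)ccc1OC(C)=O`, 1680 nM in this assay

Compound 2 stands second highest of the three numbers in this assay. Its nearest neighbour is compound 1, its furthest is compound 3, and both gaps are within the scatter, so the three measured compounds cannot be ordered against one another. Among the compounds with values here, the only single-point step among them, a 1.1-fold lower number from compound 1 to compound 2 (0.06 log units; within the scatter), is also within the scatter.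

Compound 4 `COc1ccc(Br)c(-c2nc3cc(Cl)ccc3[nH]2)c1O` differs from compound 2 by chloro in place of fluoro on an aromatic carbon. Within the data shown here, no measured step concerns exactly this swap. Compound 3 carries a chloro at the corresponding place of its core, but it differs from compound 2 elsewhere as well, so only its value and that of compound 2 can be set side by side, and they lie within the scatter of each other. The step from hydrogen to fluoro at this place, a 1.1-fold lower number from compound 1 to compound 2 (0.06 log units; within the scatter), was within the scatter, and nothing in the data points to a larger effect for chloro.

Compound 4 is therefore expected to show a step of about a 1.1-fold lower number from compound 2 to compound 4 (0.06 log units; within the scatter), that is, none beyond the scatter. The estimated half-maximal inhibitory concentration of compound 4 in this assay is 1900 nM, with a range from 950 nM to 3800 nM.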

Compound 4, half-maximal inhibitory concentration: 2210 nM
For compound 4 the middle estimate is 1.2-fold (0.07 log units) below the measured one; the measured number falls inside the stated range.
By their numbers in this assay, from the lowest: compounds 3, 2, 4 and 1 (each within the scatter of the next).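

Chloro in place of fluoro on this aromatic carbon gives a 1.0-fold higher number from compound 2 to compound 4 (0.01 log units; within the scatter), the first direct comparison of these two halogens at this place, and chloro in place of hydrogen gives a 1.1-fold lower number from compound 1 to compound 4 (0.05 log units; within the scatter). Hydrogen, fluoro and chloro can now be set side by side on the same core, and in this assay the three compounds cannot be told apart, so the earlier finding for fluoro alone now extends to a second halogen at this place. Nothing at hand explains why this place shows so little response to either halogen.

The compounds shown leave open whether a group of a different kind at this place, such as an amine, a carboxylic acid or a longer chain, would move the number beyond the scatter. Within the data shown here, they also give no single-place step anywhere else on the core, so what the bromo, hydroxyl and methoxy groups contribute to inhibition remains unknown.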